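The source may hold more compounds than are shown below. What is called first, only, known or untested is meant among the compounds shown, and "the series" means these compounds.

Three compounds of the series carry measured numbers. Compound 1 `CCC1C(=O)N(C)c2cnc(Nc3ccc(S(=O)(=O)NC)cc3)nc2N1c1ccn(C)n1` has the highest number of the three in an assay for inhibition of serine/threonine-protein kinase PLK2 (Homo sapiens), read by FRET and Z'-LYTE, with a stated time of 1 h (a lower number here means a stronger inhibitor, a higher number a weaker inhibitor), where compound 1 gives 71.6 nM. Compound 2 `CC[C@@H]1C(=O)N(C)c2cnc(-n3ccc4cc(C(N)=O)ccc43)nc2N1C1CCCC1` lies nearest to it, and in this assay compound 2 gives 28.5 nM, a lower number that lies beyond the scatter. Compound 3 `CC[C@@H]1C(=O)N(C)c2cnc(Nc3ccc(S(=O)(=O)NC)cc3)nc2N1C1CCCC1` is furthest from compound 1; in this assay compound 3 gives 3.4 nM, the lowest number of the three. Compound 4 `CCC1C(=O)N(C)c2cnc(Nc3ccc(S(=O)(=O)NCCO)cc3)nc2N1c1ccn(C)n1` has not been measured. It differs from compound 1 in one place: hydroxymethyl in place of hydrogen on a saturated chain carbon bound to a sulfonamide nitrogen. Among the measured compounds shown here, no step between two measured compounds touches this position, so the size of the step to compound 4 has no measured counterpart. The change adds a hydroxymethyl group on a saturated chain carbon bound to the sulfonamide nitrogen and leaves the rest of compound 1 untouched. For such a small addition, a step in this assay of no more than the usual scatter is expected, in either direction, so the expected step is a 1.0-fold lower number from compound 1 to compound 4 (0.01 log units; within the scatter). Compound 4 is therefore estimated at 70 nM in this assay, with a range from 30 nM to 160 nM.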

Compound 4, half-maximal inhibitory concentration: 478 nM
Compound 4: the middle estimate sits 6.8-fold (0.83 log units) below what was measured; measured number above the stated range.
By their numbers in this assay, from the lowest: compound 3; then compound 2; then compound 1; then compound 4.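

In this assay, among the compounds shown here, the change from methylsulfamoyl to (2-hydroxyethyl)sulfamoyl gives a 6.7-fold higher number from compound 1 to compound 4 (0.82 log units; beyond the scatter) and supplies the first measured step, at a position that had no measured counterpart. The position is therefore not indifferent to substitution: on the core of compound 1, adding hydroxymethyl on a saturated chain carbon bound to a sulfonamide nitrogen weakens inhibition beyond the scatter, although a single step defines no trend. Nothing available bears on what lies behind this loss, so the step stands as an observation only.

The compounds shown leave open whether the loss follows the terminal hydroxyl or the longer chain, since an ethyl or propyl group, a 2-methoxyethyl group, a 2-aminoethyl group or a carboxylic acid at this position would separate those readings. They also leave open whether the same change would cost as much on the cyclopentyl-bearing core of compound 3, where the methylsulfamoyl compound is the strongest of the series shown.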